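The compounds below may be only part of what the source reports. "The series", "measured", "known", "first", "only" and "open" are said of these compounds alone.

Working notes on the series. Each member carries the shared core with an aryl or heteroaryl carbonyl on the amide-type nitrogen. Compound 1 `CN1CCC(C(=O)N2Cc3c(NC(=O)c4cccs4)n[nH]c3C2(C)C)CC1` carries thiophen-2-yl there, and in a physicochemical assay for solubility, at pH 7 (on this read-out lower numbers stand for lower solubility and higher numbers for higher solubility), compound 1 gives 155000 nM. Compound 2 `CN1CCC(C(=O)N2Cc3c(NC(=O)c4ccc(Cl)cc4)n[nH]c3C2(C)C)CC1` carries 4-chlorophenyl in its place. In this assay compound 2 reaches only a limit of the method, > 225000 nM. Compound 3 `CN1CCC(C(=O)N2Cc3c(NC(=O)c4cccc(F)c4)n[nH]c3C2(C)C)CC1` carries 3-fluorophenyl. In this assay compound 3 likewise reads as a limit, > 225000 nM, so for compound 3 only a floor is known and no number. Two of the three values shown sit at the limit of > 225000 nM in this assay, at which 2 of the 3 values shown sit. The steps of an at least 1.4-fold higher number from compound 1 to compound 2 (0.16 log units; that floor lies within the scatter) and an at least 1.4-fold higher number from compound 1 to compound 3 (0.16 log units; that floor lies within the scatter) are readable only as floors, and the step that the two limits leave unreadable from compound 2 to compound 3 cannot be sized.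

Compound 4 `CN1CCC(C(=O)N2Cc3c(NC(=O)c4ccncc4)n[nH]c3C2(C)C)CC1` is the next member: pyridin-4-yl in place of 3-fluorophenyl on a carbonyl carbon. Among the compounds with values here, no measured step exchanges a six-membered aromatic ring of carbon only for a ring with a hetero atom, so none bears directly on this change; the two steps from compound 1 that introduce a six-membered aromatic ring of carbon only both run to the limit. The expectation is therefore that compound 4 also runs to the limit, with an expected step that the limit leaves unreadable from compound 3 to compound 4 that is not readable as a change beyond the scatter. For compound 4 the estimate is 300000 nM, within 150000 nM to 700000 nM.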

Compound 4, solubility: > 225000 nM
Compound 4: a limit, no number; the forecaster's own chance of this, stated with the estimate: 70%; the middle value does not contradict the limit.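

Of the compounds shown, compound 4 alone carries a six-membered aromatic ring with a hetero atom on this carbonyl carbon, whose other neighbour is an amide-type nitrogen, and in this assay this exchange again yields no number. Within the data shown here, the steps from compound 2 and from compound 3 to compound 4 cannot be read, and the one step that can be read gives only a floor: an at least 1.4-fold higher number from compound 1 to compound 4 (0.16 log units; that floor lies within the scatter). The new result therefore widens the range of rings at the limit without sizing any change, and the count at that limit now stands as follows: the limit of > 225000 nM in this assay, at which 3 of the 4 values shown sit.

Any order among compound 2, compound 3 and compound 4 stays open, as does whether pyridin-4-yl differs at all from 3-fluorophenyl or 4-chlorophenyl. Also open, on these data alone, is whether a different group at this place, such as a carboxylic acid on the ring, an amine on the ring or a longer alkyl chain in place of the ring, would give a readable number, as compound 1 does with 155000 nM.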